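The compounds below may be only part of what the source reports. "The series", "measured", "known", "first", "only" and "open" are said of these compounds alone.

The shared core is carried by compound 1 `C=CC[C@H]1C[C@]2([C@@H](C)Cc3cc(N)c(OC)cc3F)OCOC2=CC1=O` and compound 2 `C=CC[C@H]1C[C@]2([C@@H](C)Cc3cc(F)c(OC)cc3F)OCOC2=CC1=O`, which differ at a single aromatic carbon. In a functional assay on NCI-H460 cells (Homo sapiens) for antiproliferative activity, with a stated time of 72 h (on this read-out lower numbers stand for stronger inhibition and higher numbers for weaker inhibition), compound 1 gives 160 nM, while compound 2 gives 59 nM. The step of a 2.7-fold lower number from compound 1 to compound 2 (0.43 log units; beyond the scatter) is the only one measured so far, and it leaves compound 2 with the lowest number of the two, its nearest neighbour being compound 1.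

Compound 3 `C=CC[C@H]1C[C@]2([C@@H](C)Cc3cc(O)c(OC)cc3F)OCOC2=CC1=O` changes compound 2 at that same carbon: hydroxy in place of fluoro on an aromatic carbon. Going by the values given here, the one measured step bears on this change only loosely, since it shows that the fluoro group at this carbon went with the lower number and the amino group of compound 1 with the higher one, as the step of a 2.7-fold lower number from compound 1 to compound 2 (0.43 log units; beyond the scatter) records. By analogy a move back towards compound 1 is expected in this assay, of about a 1.9-fold higher number from compound 2 to compound 3 (0.27 log units; within the scatter), a modest rise rather than none. Compound 3 is therefore estimated at 110 nM, with a range from 50 nM to 260 nM. Whether the measurement bears this out remains to be seen.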

Compound 3, half-maximal inhibitory concentration: 33 nM
Estimate against measurement, compound 3: 3.3-fold (0.52 log units) above; the whole stated range lies above it.
By their numbers in this assay, from the lowest: compounds 3 and 2 (each within the scatter of the next); then compound 1.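

In this assay, hydroxy in place of fluoro gives a 1.8-fold lower number from compound 2 to compound 3 (0.25 log units; within the scatter), so the two groups cannot be told apart at this carbon, ortho to a methoxy group and para to a fluoro group, although hydroxy counts 1 hydrogen-bond donor and 1 hydrogen-bond acceptor and fluoro counts neither. Going by these compounds alone, the earlier step could not show this, but hydroxy in place of amino now gives a 4.8-fold lower number from compound 1 to compound 3 (0.69 log units; beyond the scatter), which, with a 2.7-fold lower number from compound 1 to compound 2 (0.43 log units; beyond the scatter), leaves amino as the only one of the three groups set apart from the others, with the weakest inhibition in this small set. Nothing given here explains why amino stands apart from fluoro and hydroxy at this carbon.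

On these data alone, three groups at one carbon on one core in one cell line make a narrow basis, and it remains open whether a chloro, methyl or methoxy group here would fall with fluoro and hydroxy or with amino. As far as these compounds go, a carboxylic acid or a longer chain such as ethoxy at this carbon is equally open, as is whether the same reading would hold on another cell line.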